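The compounds below may be only part of what the source reports. "The series", "measured", "known", "first", "only" and "open" are said of these compounds alone.

Compound 1 `O=C(Nc1cccc2[nH]ncc12)N[C@@H]1CCOc2cc(C(F)(F)F)ccc21` — a functional assay for antagonist activity at transient receptor potential cation channel subfamily V member 1 (Homo sapiens), read by calcium flux (a higher number here means a weaker inhibitor, a lower number a stronger inhibitor), 4 nM
Compound 2 `O=C(Nc1cccc2[nH]ncc12)N[C@H]1CCOc2cc(C(F)(F)F)ccc21` — this assay 43 nM

Compound 2 gives the highest number of the two. Among the compounds with values here, its only measured neighbour is compound 1, and the step of an 11-fold higher number from compound 1 to compound 2 (1.03 log units; beyond the scatter) rests on (the fact that compounds 1 and 2 differ only in the configuration as drawn). Compound 3 `CC(C)(C)c1ccc2c(c1)OCC[C@@H]2NC(=O)Nc1cccc2[nH]ncc12` is compound 2 with tert-butyl in place of trifluoromethyl on an aromatic carbon. Within the data shown here, no measured step touches this position; the one step in hand concerns configuration, not this substituent, so it gives no direction. Compound 3 is therefore expected to sit close to compound 2 in this assay, the estimated step being a 1.2-fold higher number from compound 2 to compound 3 (0.07 log units; within the scatter), around 50 nM with a range of 15 nM to 170 nM.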

Compound 3, half-maximal inhibitory concentration: 1200 nM
Compound 3: the middle estimate sits 24-fold (1.38 log units) below what was measured; measured number above the stated range.
By their numbers in this assay, from the lowest: compound 1; then compound 2; then compound 3.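

At this aromatic carbon, para to a fused ring and meta to a fused ring, the substituent matters in this assay: tert-butyl in place of trifluoromethyl gives a 28-fold higher number from compound 2 to compound 3 (1.45 log units; beyond the scatter). The two groups have the same count of heavy atoms, and neither has hydrogen-bond donors, hydrogen-bond acceptors or a net charge, so those counts alone do not decide the result here. Nothing at hand on these compounds accounts for this step. The compounds shown leave open how a chlorine or a nitrile would fare at this position, and whether the same exchange on compound 1 would give a step of similar size.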